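From (4-fluorophenyl)sulfanyl to (4-fluorobenzyl)amino on a Shared Core

A few compounds are considered here, and "the series" means these few. Any claim that something is new, unique, unknown or untested is made for them only; others in the source may bear on it.

Compound 1 `CCOC(=O)[C@H](CCC(=O)O)NC(=O)c1ccc(Sc2nc3cc(N)cc(N)c3nc2-c2ccccc2)cc1`: < 100000 nM
Compound 2 `Nc1cc(N)c2nc(-c3ccccc3)c(Sc3ccc(F)cc3)nc2c1`: < 100000 nM
Compound 3 `CCOC(=O)[C@H](CCC(=O)O)NC(=O)c1ccc(Oc2nc3cc(N)cc(N)c3nc2-c2ccccc2)cc1`: < 100000 nM

In a functional assay on COLO 205 cells (Homo sapiens) for inhibition, read by sulforhodamine B assay, with a stated time of 48 h (a lower number here means that less compound is tolerated, a higher number that more compound is tolerated), compound 2 gives only a limit, < 100000 nM, and not a number. Compound 1 likewise reaches only a limit in this assay, < 100000 nM. Compound 3 too stands at a limit in this assay, < 100000 nM. So compound 2 cannot be placed above or below its companions: the limit of < 100000 nM in this assay, at which 3 of the 3 values shown sit, and nothing among the three separates them.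

Compound 4 `Nc1cc(N)c2nc(-c3ccccc3)c(NCc3ccc(F)cc3)nc2c1` is the untested partner of compound 2. The change is (4-fluorobenzyl)amino in place of (4-fluorophenyl)sulfanyl on an aromatic carbon. For the measured compounds named here, no step between measured compounds is on record, so the size of this step in this assay can only be guessed; the most likely outcome is that compound 4 stays at the same limit, with no step beyond the scatter.

Compound 4 is therefore expected near 30000 nM, within 5000 nM to 100000 nM, which means an estimated step that the limit leaves unreadable from compound 2 to compound 4.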

Compound 4, concentration lethal to 50% of the cells: < 100000 nM
Compound 4 gave a limit, no number (the forecaster's own chance of this, stated with the estimate: 70%); the middle value is on the limit's open side.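

In this assay compound 4 gives only a limit, < 100000 nM. Compound 2 also stands at a limit, so no step can be read between compound 2 and compound 4: the limit of < 100000 nM in this assay, at which 4 of the 4 values shown sit. The compounds shown leave open whether (4-fluorobenzyl)amino in place of (4-fluorophenyl)sulfanyl changes the value at all, and how the four compounds rank against one another.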